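The compounds below may be only part of what the source reports. "The series", "measured", "known", "first", "only" and "open" are said of these compounds alone.

Working notes on the series. Compound 1 `NS(=O)(=O)c1ccc(N2N=C(c3ccccc3)CC2c2ccccc2F)cc1` is measured in an ADME assay on MT4 cells (Homo sapiens) for cytotoxicity, read by MTT assay, with a stated time of 96 h (a lower number here means that less compound is tolerated, a higher number that more compound is tolerated), at 42000 nM. Among the measured compounds shown here, compound 3 `NS(=O)(=O)c1ccc(N2N=C(c3ccccc3)CC2c2ccccc2Cl)cc1` carries chloro in place of fluoro on an aromatic carbon, and in this assay compound 3 gives 44000 nM; the step of a 1.0-fold higher number from compound 1 to compound 3 (0.02 log units; within the scatter) is the only measured step in the set. Compound 2 `Cc1ccccc1C1CC(c2ccc(OCc3ccccc3)cc2)=NN1c1ccc(S(N)(=O)=O)cc1` is known in this assay only as a limit, >= 100000 nM, which is the boundary (the limit of >= 100000 nM in this assay, at which 1 of the 3 values shown sits). Compound 4 `NS(=O)(=O)c1ccc(N2N=C(c3ccc(OCc4ccccc4)cc3)CC2c2ccc(F)cc2)cc1` is not yet measured; it differs from compound 2 in one place: 4-fluorophenyl in place of 2-methylphenyl on a saturated ring carbon. For the measured compounds named here, no measured pair exchanges a 2-methylphenyl for a 4-fluorophenyl, so the step from compound 1 to compound 3, which stayed within the scatter, is the nearest guide and suggests no large shift in this assay from such an aryl substituent exchange. Compound 4 is therefore expected to sit near the same boundary, with an expected step of an at least 1.1-fold lower number from compound 2 to compound 4 (0.04 log units; that floor lies within the scatter). The estimate for compound 4 in this assay is 90000 nM, with a range from 40000 nM to 200000 nM.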

Compound 4, half-maximal cytotoxic concentration: > 100000 nM
Compound 4: a limit, no number (the forecaster's own chance of this, stated with the estimate: 55%); middle value at least 1.1-fold (0.04 log units) from the limit.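

Among the compounds shown here, compound 2 and compound 4 are both known in this assay only as limits, so no step between them can be read. The compounds shown leave open whether 4-fluorophenyl in place of 2-methylphenyl on the saturated ring carbon changes the tolerated concentration at all.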